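The compounds below may be only part of what the source reports. "The series", "measured", "known", "first", "only" and "open" are said of these compounds alone.

In a physicochemical assay for solubility, read by LC-MS, in phosphate buffer, measured as thermodynamic solubility, with a stated time of 24 h, at pH 7.4 (a lower number here means a less soluble compound, a higher number a more soluble compound), compound 1 `COc1ccc(-c2c[nH]c3ncc(-c4cnn(C)c4)cc23)cc1` gives 5000 nM. Compound 2 `Cn1cc(-c2cnc3[nH]cc(-c4ccc(O)cc4)c3c2)cn1` gives only a limit in this assay, < 3000 nM. For the measured compounds named here, the one measured step is an at least 1.6-fold lower number from compound 1 to compound 2 (0.22 log units; that floor lies within the scatter). Compound 3 `Cc1nn(C)cc1-c1cnc2[nH]cc(-c3cccc(C#N)c3)c2c1` gives 2000 nM in this assay, the lowest of the two numbers shown, and its gap to compound 1 lies beyond the scatter. Compound 4 `CN1CCCN(c2cnc3[nH]cc(-c4cccc(C#N)c4)c3c2)CC1` differs from compound 3 in one place: 4-methyl-1,4-diazepan-1-yl in place of 1,3-dimethyl-1H-pyrazol-4-yl on an aromatic carbon. Going by the values given here, none of the measured steps exchanges one ring for another of this kind, so no measured step bears on this change, and the expectation rests on the change itself. Compound 4 is expected in this assay at 15000 nM, estimated between 3000 nM and 80000 nM. That estimate corresponds to an expected step of a 7.5-fold higher number from compound 3 to compound 4 (0.88 log units; beyond the scatter).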

Compound 4, solubility: 690000 nM
For compound 4 the middle estimate is 46-fold (1.66 log units) below the measured one, outside the stated range (above it).
By their numbers in this assay, from the lowest: compound 3; then compound 1; then compound 4.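

In this assay, the ring on this aromatic carbon, two atoms from the ring nitrogen, turns out to matter greatly: 4-methyl-1,4-diazepan-1-yl in place of 1,3-dimethyl-1H-pyrazol-4-yl gives a 350-fold higher number from compound 3 to compound 4 (2.54 log units; beyond the scatter) on the shared core. The earlier step, on an oxygen elsewhere in the molecule, said nothing about this position. Nothing shown here accounts for the size of this step.

Going by these compounds, what carries the step stays open: the seven-membered ring, its non-aromatic character or its methyl group. A piperazine, a morpholine or an open-chain amine on this carbon would help separate these.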